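A Chloro for a Fluoro on the Benzyl Ether

A few compounds are considered here, and "the series" means these few. Any claim that something is new, unique, unknown or untested is made for them only; others in the source may bear on it.

Compound 1 `COc1cc(OC)c(-c2coc3cc(OCc4ccccc4F)ccc3c2=O)cc1OC` holds the lowest of the three measured numbers in a functional assay on U-251 cells (Homo sapiens) for antiproliferative activity, read by MTT assay, with a stated time of 24 h (a lower number here means a stronger inhibitor, a higher number a weaker inhibitor), where compound 1 gives 2890 nM. Compound 2 `COc1cc(OC)c(-c2coc3cc(OCc4ccc([N+](=O)[O-])cc4)ccc3c2=O)cc1OC` gives 9400 nM, and compound 3 `COc1cc(OC)c(-c2coc3cc(OCc4ccc(C#N)cc4)ccc3c2=O)cc1OC` gives 6180 nM. Both steps away from the lowest number lead upward: a 3.3-fold higher number from compound 1 to compound 2 (0.51 log units; beyond the scatter) and a 2.1-fold higher number from compound 1 to compound 3 (0.33 log units; beyond the scatter), while a 1.5-fold lower number from compound 2 to compound 3 (0.18 log units; within the scatter), within the scatter.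

Compound 4 `COc1cc(OC)c(-c2coc3cc(OCc4ccccc4Cl)ccc3c2=O)cc1OC` differs from compound 1 by a single atom: chloro in place of fluoro on an aromatic carbon. The change sits on an aromatic carbon of a six-membered aromatic ring of carbon only, ortho to a large group.

For the measured compounds named here, none of the measured steps touches this exact exchange. The two steps from compound 1 swap the whole 2-fluorophenyl for 4-nitrophenyl or 4-cyanophenyl, changing both the group and its place, and still gave only modest rises; the swap of cyano for nitro stayed within the scatter. A single-atom halogen exchange is a smaller change than any of these, so no step beyond the scatter in this assay is expected in either direction. Compound 4 is therefore estimated at 2600 nM, with a range of 1200 nM to 6000 nM. The step this implies is expected to be a 1.1-fold lower number from compound 1 to compound 4 (0.05 log units; within the scatter).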

Compound 4, half-maximal inhibitory concentration: > 10000 nM
Compound 4: a limit, no number; the forecaster's own chance of this, stated with the estimate: 3%; middle value at least 3.8-fold (0.58 log units) from the limit.
By their numbers in this assay, from the lowest: compound 1; then compounds 3 and 2 (each within the scatter of the next). At a limit, above all of these: compound 4.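

The exchange of fluoro for chloro on an aromatic carbon, ortho to a large group, shows that this place on the benzyl ether is sensitive to a single atom: an at least 3.4-fold higher number from compound 1 to compound 4 (0.53 log units; beyond the scatter). The earlier steps shown here from compound 1 replaced the whole 2-fluorophenyl, so they could not show that one halogen alone moves the number beyond the scatter. In this assay compound 4 gives > 10000 nM, a limit of the assay and not a number: the limit of > 10000 nM in this assay, at which 1 of the 4 values shown sits.

Against the other two compounds only floors can be read, an at least 1.6-fold higher number from compound 3 to compound 4 (0.20 log units; that floor lies within the scatter) and an at least 1.0-fold higher number from compound 2 to compound 4 (0.02 log units; that floor lies within the scatter), so the place of compound 4 relative to them stays unsettled, and how far its true number lies past the limit is unknown. The compounds shown also leave open whether a bromo group, a methyl group or a plain hydrogen at this same place would stay close to compound 1 or go the way of compound 4, and so whether fluoro or chloro is the unusual case.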